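Chloro Added to Compound 1: Expected Antiproliferative Effect

This account rests on a few compounds, and the source may have more. Where it says the series, first, only, none or still open, it means among the compounds named here.

Measured compounds:
compound 1 `Cn1c(N2N=C(c3ccccc3)CC2c2ccc(Cl)cc2)nc(-c2ccccc2)c(C#N)c1=O` — 19200 nM
compound 2 `Cn1c(N2N=C(c3ccccc3)CC2c2ccc(F)cc2)nc(-c2ccccc2)c(C#N)c1=O` — 8150 nM

Going by the values given here, compound 1 has been tested in a functional assay on HT-29 cells (Homo sapiens) for antiproliferative activity, with a stated time of 72 h (on this read-out lower numbers stand for stronger inhibition and higher numbers for weaker inhibition), where compound 1 gives 19200 nM, the highest of the two numbers so far. Among the compounds with values here, the only measured neighbour is compound 2, reached by a 2.4-fold lower number from compound 1 to compound 2 (0.37 log units; beyond the scatter), a fluoro in place of chloro on an aromatic carbon.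

Compound 3 `Cn1c(N2N=C(c3ccccc3)CC2c2ccc(Cl)cc2)nc(-c2ccc(Cl)cc2)c(C#N)c1=O` is the unmeasured compound. Relative to compound 1 it carries chloro in place of hydrogen on an aromatic carbon, on the phenyl attached to the shared core rather than on the chlorophenyl that compound 1 and compound 2 share.

Within the data shown here, no measured step involves a chloro entering in place of hydrogen, so nothing directly bears on this change. Among the measured compounds shown here, the single known step, a 2.4-fold lower number from compound 1 to compound 2 (0.37 log units; beyond the scatter), alters a halogen on a different aromatic carbon and was modest in size. The expectation for compound 3 in this assay is therefore no step beyond the scatter, with the direction uncertain. Compound 3 is estimated at 15000 nM, within 5000 nM to 45000 nM. This estimate means an expected step of a 1.3-fold lower number from compound 1 to compound 3 (0.11 log units; within the scatter).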

Compound 3, half-maximal inhibitory concentration: 15000 nM
Beside the measured number, compound 3's estimate shows no gap at the digits printed; the range from low to high includes it.
By their numbers in this assay, from the lowest: compounds 2, 3 and 1 (each within the scatter of the next, the first and the last beyond it).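

In this assay, replacing phenyl with 4-chlorophenyl gives a 1.3-fold lower number from compound 1 to compound 3 (0.11 log units; within the scatter), so this assay does not separate compound 3 from compound 1. Going by these compounds alone, the earlier pair differed only in the halogen on the other aromatic ring, so this is the first information about the phenyl attached to the shared core, and it shows that a chloro entering on this aromatic carbon, para to a large group, produces no step beyond the scatter. Nothing measured here offers an explanation for this outcome.

On these data alone, a single chloro says little about this position as a whole, and it remains open whether a fluoro, a methoxy group, an amine or a carboxylic acid on the same carbon would also stay within the scatter or would move the number beyond it in either direction. Within the data shown here, it also remains open whether the chloro would give the same result with the fluoro of compound 2 on the other ring, since the step from compound 1 to compound 2 has so far been seen only with an unsubstituted phenyl at this place.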